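Swapping Chloro for Methoxy on an Aromatic Carbon

The compounds below may be only part of what the source reports. "The series", "measured", "known", "first", "only" and "open" are said of these compounds alone.

Compound 1 `CN(C)CC1Cc2ccccc2C1=O`: 0.167 h
Compound 2 `O=C1c2ccccc2CC1CN1CCCCC1`: 0.267 h
Compound 3 `CN(C)CC1Cc2cc(Cl)ccc2C1=O`: 0.117 h

All three half-lives come from a physicochemical assay for pharmacokinetics, read by HPLC, at pH 7.5, tested at 250 uM; a lower number here means that the compound disappears faster, a higher number that the compound lasts longer. Compound 3, at 0.117 h, cannot be told apart from compound 1, at 0.167 h, since the two lie within the scatter of each other. Compound 2, at 0.267 h, stands clear of compound 3 with a higher number.

The next compound to be measured is compound 4 `COc1ccc2c(c1)CC(CN(C)C)C2=O`, which carries methoxy in place of chloro on an aromatic carbon. Going by the values given here, the only measured step at this aromatic carbon is a 1.4-fold lower number from compound 1 to compound 3 (0.15 log units; within the scatter), where chloro took the place of hydrogen. That step is small and does not rise above the scatter. Compound 2 differs from the others elsewhere in the structure, so it offers no guide to this change. Among the compounds with values here, no methoxy compound has been measured, so the evidence is thin, and no step beyond the scatter is expected in this assay in either direction.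

The estimated step is a 1.4-fold higher number from compound 3 to compound 4 (0.14 log units; within the scatter), which is expected to stay within the scatter. Compound 4 is expected at 0.16 h, with an estimated range of 0.09 h to 0.29 h.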

Compound 4, half-life: 0.75 h
Estimate against measurement, compound 4: 4.7-fold (0.67 log units) below, and the stated range ends below it.
By their numbers in this assay, from the lowest: compounds 3, 1 and 2 (each within the scatter of the next, the first and the last beyond it); then compound 4.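

The earlier compounds shown here made this aromatic carbon look insensitive, with chloro in place of hydrogen giving only a 1.4-fold lower number from compound 1 to compound 3 (0.15 log units; within the scatter) in this assay. Methoxy changes that picture, giving a 6.4-fold higher number from compound 3 to compound 4 (0.81 log units; beyond the scatter) and also a 4.5-fold higher number from compound 1 to compound 4 (0.65 log units; beyond the scatter) in the same assay. The position therefore does respond to the group it carries, and in these three compounds methoxy stands apart from both hydrogen and chloro, while those two remain within the scatter of each other. No measurement shown here accounts for the size of these steps, so the reason for them remains unknown.

On these data alone, with methoxy represented by compound 4 alone, it remains open whether the longer half-life belongs to methoxy specifically or would also appear with ethoxy, hydroxy, fluoro or an amine on the same aromatic carbon. Going by these compounds alone, it is equally open whether methoxy would give a similar step when paired with the amine of compound 2, as the step has been seen only with the dimethylamino side chain shared by compound 1, compound 3 and compound 4.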